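The source may hold more compounds than are shown below. What is called first, only, known or untested is meant among the compounds shown, and "the series" means these compounds.

Of the compounds shown here, three that share one core have been measured in a functional assay on T47D cells (Homo sapiens) for inhibition, read by sulforhodamine B assay, with a stated time of 48 h, tested at 1 uM; on this read-out lower numbers stand for a stronger effect and higher numbers for a weaker effect at the one concentration tested. Compound 1 `O=C(Nc1cccc(-n2cc(-c3ccncc3)c(-c3cc(O)cc(Cl)c3)n2)c1)Nc1ccc(Cl)c(Cl)c1` gives 96%, compound 2 `COc1cc(Cl)cc(-c2nn(-c3cccc(NC(=O)Nc4ccc(Cl)c(C(F)(F)F)c4)c3)cc2-c2ccncc2)c1` gives 58%, and compound 3 `COc1cc(Cl)cc(-c2nn(-c3cccc(NC(=O)Nc4ccc(Cl)c(Cl)c4)c3)cc2-c2ccncc2)c1` gives 87%. Among these three numbers compound 3 stands second highest: the step of a number 9 percentage points lower from compound 1 to compound 3 (within the scatter) lies within the scatter, so those two cannot be told apart, while the step of a number 29 percentage points higher from compound 2 to compound 3 (beyond the scatter) is beyond the scatter, so compound 2 shows a clearly stronger effect than compound 3.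

Compound 4 `COc1cc(Cl)cc(-c2nn(-c3cccc(NC(=O)c4cccc(C(F)(F)F)c4)c3)cc2-c2ccncc2)c1` has not been measured. It differs from compound 3 in one place: 3-(trifluoromethyl)phenyl in place of (3,4-dichlorophenyl)amino on a carbonyl carbon. Among the measured compounds shown here, no measured step alters this part of the molecule in the same way. The step of a number 29 percentage points higher from compound 2 to compound 3 (beyond the scatter) shows that a trifluoromethyl in that region of the molecule went with a lower number, whereas a number 9 percentage points lower from compound 1 to compound 3 (within the scatter) concerns a distant methyl and offers no guidance here. As far as these compounds go, because compound 2, which also carries a trifluoromethyl, gives 58%, a somewhat lower number than that of compound 3 is expected, but the loss of the hydrogen-bond donor is untested, so the range is wide. Compound 4 is therefore estimated at 72%, with a likely span from 45% to 100%, which means an expected step of a number 15 percentage points lower from compound 3 to compound 4 (beyond the scatter).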

Compound 4, a percentage reported as activity, at one concentration (the size of the read-out at that concentration, not a potency): 92%
The estimate for compound 4 lay 20 percentage points below the measured number, within the range that was stated.
By their numbers in this assay, from the lowest: compound 2; then compounds 3, 4 and 1 (each within the scatter of the next).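

In this assay, putting 3-(trifluoromethyl)phenyl in place of (3,4-dichlorophenyl)amino on the carbonyl carbon gives a number 5 percentage points higher from compound 3 to compound 4 (within the scatter), so these two groups cannot be told apart here, even though the entering group has no hydrogen-bond donor and the leaving group has one. The earlier compounds shown here left open whether a trifluoromethyl could carry the stronger effect at this end of the molecule, but here a trifluoromethyl on the phenyl ring is not enough on its own: replacing (4-chloro-3-(trifluoromethyl)phenyl)amino with 3-(trifluoromethyl)phenyl gives a number 34 percentage points higher from compound 2 to compound 4 (beyond the scatter), a clear weakening of the effect. No measurement is available that explains either result.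

This single change removes both the chloro and the amino link, so the compounds shown cannot say which of the two matters, and 4-chloro-3-(trifluoromethyl)phenyl placed directly on the carbonyl carbon would be needed to separate them. They also leave open how a phenyl ring carrying a nitrile, or a carboxylic acid, would behave on this carbonyl carbon.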